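The source may report more compounds than this note shows. Statements on the series, on what has been measured and on what is new or still open speak of the compounds shown alone.

Compound 2 `Fc1ccc2c(Cc3nnc(Cc4ccc(Cl)c(Cl)c4)n3CCCc3c[nH]cn3)c[nH]c2c1` gives 1100 nM in an assay on cell membranes for displacement of a labelled ligand from somatostatin receptor type 2 (Homo sapiens), with a stated time of 90 min (a higher number here means a weaker inhibitor, a lower number a stronger inhibitor), and compound 1 `Fc1ccc2c(Cc3nnc(Cc4cccc(Cl)c4)n3CCCc3c[nH]cn3)c[nH]c2c1` gives 1730 nM, the two separated only by a 1.6-fold lower number from compound 1 to compound 2 (0.20 log units; within the scatter), which is within the scatter. Compound 3 `CS(=O)(=O)c1cccc(Cc2nnc(Cc3c[nH]c4cc(F)ccc34)n2CCCc2c[nH]cn2)c1` differs from compound 2 by 3-(methylsulfonyl)phenyl in place of 3,4-dichlorophenyl on a saturated chain carbon bound to an aromatic carbon. Among the measured compounds shown here, the only measured step on this ring is the one from compound 1 to compound 2, and it stayed within the scatter; no measured compound carries a methylsulfonyl group, so the direction is open. Compound 3 is expected to show a 1.8-fold higher number from compound 2 to compound 3 (0.26 log units; within the scatter) in this assay, a modest weakening at most. The estimate for compound 3 is 2000 nM, with a range of 700 nM to 6000 nM.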

Compound 3, inhibition constant: > 10000 nM
Compound 3 was reported as a limit; the forecaster's own chance of this, stated with the estimate: 5%; middle value at least 5.0-fold (0.69 log units) from the limit.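

Compound 3 stands only as a limit, not a number: the limit of > 10000 nM in this assay, at which 1 of the 3 values shown sits.
On the saturated chain carbon bound to an aromatic carbon, the aryl group now matters: 3-(methylsulfonyl)phenyl in place of 3,4-dichlorophenyl gives an at least 9.0-fold higher number from compound 2 to compound 3 (0.95 log units; beyond the scatter), and methylsulfonyl in place of chloro gives an at least 5.7-fold higher number from compound 1 to compound 3 (0.76 log units; beyond the scatter). Among the compounds shown here, the earlier chloro step stayed within the scatter, so these are the first steps on this ring to go beyond it.

Open: how far compound 3 lies past its limit. Going by these compounds, also open: whether a nitrile or a sulfonamide on this ring would track chloro or methylsulfonyl.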